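This account rests on a few compounds, and the source may have more. Where it says the series, first, only, none or still open, it means among the compounds named here.

Measured so far:
compound 1 `O=C(Nc1cccc(-n2cc(-c3ccncc3)c(-c3cc(O)cc(Cl)c3)n2)c1)Nc1ccc(Cl)c(C(F)(F)F)c1`: 5.34%
compound 2 `COc1cc(Cl)cc(-c2nn(-c3cccc(NC(=O)Nc4ccc(Cl)c(C(F)(F)F)c4)c3)cc2-c2ccncc2)c1`: -13%
compound 3 `COc1cc(Cl)cc(-c2nn(-c3cccc(NC(=O)Nc4cc(C(F)(F)F)cc(C(F)(F)F)c4)c3)cc2-c2ccncc2)c1`: -6.27%

In a functional assay on PC-3 cells (Homo sapiens) for inhibition, read by sulforhodamine B assay, with a stated time of 48 h, tested at 10 uM (a higher number here means a weaker effect of the compound at the concentration tested, a lower number a stronger effect), compound 2 gives -13%, the lowest of the three numbers. Compound 3 stands closest to it, and the two lie within the scatter of each other, so nothing separates them. Compound 1 stands furthest away, and the step of a number 18.3 percentage points lower from compound 1 to compound 2 (beyond the scatter) is beyond the scatter.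

The step to compound 4 `COc1cc(Cl)cc(-c2nn(-c3cccc(NC(=O)c4cccc(C(F)(F)F)c4)c3)cc2-c2ccncc2)c1` takes the shared core of compound 2 and changes one place: 3-(trifluoromethyl)phenyl in place of (4-chloro-3-(trifluoromethyl)phenyl)amino on a carbonyl carbon. Among the compounds with values here, the only measured step, from compound 1 to compound 2, concerns a different place on the molecule and gives no guidance on this change. Compound 2 and compound 3 differ on the same aryl group that is altered here, and their numbers lie within the scatter, which hints that changes at this end were tolerated there; but the loss of the amino part is larger than that difference. A modest step in this assay towards a higher number, a weaker effect, is expected for compound 4, namely a number 28 percentage points higher from compound 2 to compound 4 (beyond the scatter). Compound 4 is therefore estimated at 15%, within a range from -15% to 50%.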

Compound 4, a percentage reported as activity, at one concentration (the size of the read-out at that concentration, not a potency): 23.1%
The estimate for compound 4 lay 8.1 percentage points below the measured number, and the stated range covers the measured number.
By their numbers in this assay, from the lowest: compounds 2 and 3 (each within the scatter of the next); then compound 1; then compound 4.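

In this assay, this end of the molecule proves to matter: putting 3-(trifluoromethyl)phenyl in place of (4-chloro-3-(trifluoromethyl)phenyl)amino on a carbonyl carbon gives a number 36.1 percentage points higher from compound 2 to compound 4 (beyond the scatter), a large step towards a weaker effect, whereas the numbers of compound 2 and compound 3, which differ on the same aryl group, lie within the scatter of each other. The change removes the amino nitrogen, with its hydrogen-bond donor, and the chlorine together, so this single step cannot show which loss matters. No measurement here explains the step.

A compound carrying (3-(trifluoromethyl)phenyl)amino on the carbonyl carbon would separate the two losses. Going by these compounds, whether 4-chloro-3-(trifluoromethyl)phenyl attached directly to that carbon would restore the effect also remains open.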